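Swapping the amide cap on a stable scaffold

A few compounds are considered here, and "the series" means these few. Any claim that something is new, unique, unknown or untested is made for them only; others in the source may bear on it.

Compound 2 `COc1ccc(-c2c(C)nc3c(N4CC[C@@H](NC(=O)c5ccccc5)C4)cc(C)nn23)cc1OC` carries a benzamido group on the shared core. In an ADME assay on microsomes from liver (Mus musculus) for metabolic stability, read by LC-MS, with NADPH named in the record, with a stated time of 60 min, tested at 1 uM, in the absence of a further agent (on this read-out higher numbers stand for a more stable compound and lower numbers for a less stable compound), compound 2 gives > 95%, which is a limit of the assay and not a number. The closest comparison is compound 1 `COc1ccc(-c2c(C)nc3c(N4CC[C@@H](NC(C)=O)C4)cc(C)nn23)cc1OC`, in which the carbonyl carbon bears a methyl instead of a phenyl. In this assay compound 1 gives > 95%, again a limit of the assay. The step that the two limits leave unreadable from compound 1 to compound 2 therefore cannot be sized, because both values sit at the limit of > 95% in this assay, at which 2 of the 2 values shown sit. Compound 3 `COc1ccc(-c2c(C)nc3c(N4CC[C@@H](NC(=O)C(F)(F)F)C4)cc(C)nn23)cc1OC` differs from compound 2 by trifluoromethyl in place of phenyl on a carbonyl carbon. Going by the values given here, the one measured step that bears on this change is unreadable, so neither a direction nor a size beyond the scatter can be taken from it. Compound 3 is expected to remain near the limit, with an estimated step of a number at least 2 percentage points lower from compound 2 to compound 3 (that floor lies within the scatter). The estimated value for compound 3 is 93%, between 75% and 99%.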

Compound 3, percent of the compound remaining: > 95%
Compound 3 ended at the assay's limit; the forecaster's own chance of this, stated with the estimate: 60%; at least 2 percentage points between middle value and limit.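

In this assay compound 3 gives > 95%, which is a limit of the assay and not a number. Going by these compounds alone, no step among compound 1, compound 2 and compound 3 can be read, because all three stop at the same limit: the limit of > 95% in this assay, at which 3 of the 3 values shown sit. On these data alone, whether methyl, phenyl and trifluoromethyl on the carbonyl carbon differ at all in stability stays open.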